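Para-Bromo for Para-Fluoro on a Dihydrostilbene Scaffold

This account rests on a few compounds, and the source may have more. Where it says the series, first, only, none or still open, it means among the compounds named here.

The two measured compounds share the core of compound 1 `COc1cc(CCc2ccc(F)cc2)cc(OC)c1O` and differ only in the halogen pattern of the second ring. In a functional assay on A549 cells (Homo sapiens) for antiproliferative activity, read by MTT assay, with a stated time of 72 h (a higher number here means a weaker inhibitor, a lower number a stronger inhibitor), compound 1 gives 4150 nM. Compound 2 `COc1cc(CCc2cccc(Cl)c2Cl)cc(OC)c1O` in this assay gives 3990 nM; the two values lie within the scatter of each other, so neither compound can be placed above the other. Compound 3 `COc1cc(CCc2ccc(Br)cc2)cc(OC)c1O` has not yet been measured in this assay. It differs from compound 1 in one place: bromo in place of fluoro on an aromatic carbon. Within the data shown here, no step between two measured compounds isolates this exchange, so the expectation rests on the single measured pair and the nature of the change. A modest move is expected, at most at the edge of the scatter, toward a slightly lower number, a 1.4-fold lower number from compound 1 to compound 3 (0.14 log units; within the scatter). Compound 3 is therefore estimated at 3000 nM in this assay, with a range from 1200 nM to 7500 nM.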

Compound 3, half-maximal inhibitory concentration: > 25000 nM
Compound 3 was reported as a limit; the forecaster's own chance of this, stated with the estimate: 3%; at least 8.3-fold (0.92 log units) between middle value and limit.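

In this assay, changing the halogen on this aromatic carbon, para to a large group, is not a neutral exchange: the step is an at least 6.0-fold higher number from compound 1 to compound 3 (0.77 log units; beyond the scatter). The single halogen at this position can therefore decide the read-out, which compound 1 on its own could not show, and this one atom change is enough to produce a step beyond the scatter. The reading for compound 3 is a limit of the assay and not a number, so the full size of the step stays unknown: the limit of > 25000 nM in this assay, at which 1 of the 3 values shown sits.

Going by these compounds, whether a single chloro, a methyl or a methoxy group at this position would read like compound 1 or like compound 3 remains open. The compounds shown also do not tell what lies behind the step, or whether the same exchange elsewhere on this ring would act alike.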